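Working notes: from compound 2 to compound 4

The source may report more compounds than this note shows. Statements on the series, on what has been measured and on what is new or still open speak of the compounds shown alone.

Measured so far in an ADME assay on L02 cells (Homo sapiens) for inhibition, read by CCK-8 assay, with a stated time of 48 h (on this read-out lower numbers stand for stronger inhibition of growth and higher numbers for weaker inhibition of growth), for this series:
- compound 1 `Cc1ccccc1Nc1nc(Nc2cccnc2)ncc1Cl` gives 22900 nM as a number
- compound 2 `Cc1ccccc1Nc1nc(Nc2ccccc2)ncc1Cl` gives > 100000 nM as a limit, not a number
- compound 3 `Cc1ccccc1Nc1nc(NCc2ccco2)ncc1Cl` gives > 100000 nM as a limit, not a number

Compound 2 carries only a limit, and it is not alone there (the limit of > 100000 nM in this assay, at which 2 of the 3 values shown sit). Compound 4 `Cc1ccccc1Nc1nc(Nc2ccc(N3CCCN(C)CC3)cc2)ncc1Cl` keeps everything in compound 2 and changes one place: 4-methyl-1,4-diazepan-1-yl in place of hydrogen on an aromatic carbon in words, 4-methyl-1,4-diazepan-1-yl in place of hydrogen on an aromatic carbon of the six-membered aromatic ring of carbon only, para to a large group.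

For the measured compounds named here, three measured steps concern the same nitrogen substituent. These are an at least 4.3-fold higher number from compound 1 to compound 2 (0.64 log units; beyond the scatter) and an at least 4.3-fold higher number from compound 1 to compound 3 (0.64 log units; beyond the scatter), each beyond the scatter, and a step that the two limits leave unreadable from compound 2 to compound 3 without a readable size. None of them adds a group to the phenyl ring, so they offer no direct size for this change. The expectation rests on compound 1, which at 22900 nM shows that a change on that nitrogen can give a reading that is a number. A modest move towards stronger inhibition of growth is therefore expected in this assay, and a reading that again stays at the limit remains possible. The expected step is an at least 4.0-fold lower number from compound 2 to compound 4 (0.60 log units; beyond the scatter) on this estimate. Compound 4 is estimated at 25000 nM with an expected range from 6000 nM to 90000 nM in this read-out.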

Compound 4, concentration for 50% growth inhibition: 1240 nM
Estimate against measurement, compound 4: 20-fold (1.30 log units) above; measured number below the stated range.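

Adding 4-methyl-1,4-diazepan-1-yl on an aromatic carbon of the phenyl ring, para to a large group, gives in this assay an at least 80-fold lower number from compound 2 to compound 4 (1.90 log units; beyond the scatter), so this ring carbon is a place where a single change moves the reading from a limit to a number. Compounds 1, 2 and 3 differ only in the group on the nitrogen and carry nothing on this carbon, so they could not show that substitution here has any effect, nor one of this size. Compound 2 has only a limit and not a number, so the printed step is a bound and the full size of the change cannot be read: the limit of > 100000 nM in this assay, at which 2 of the 4 values shown sit.

The compounds shown leave open whether the step depends on the seven-membered ring, on its two nitrogen atoms or on the terminal methyl, which a piperazine, a morpholine or an open-chain amine on the same carbon would help to separate. Also open, from the compounds shown here alone, is whether 4-methyl-1,4-diazepan-1-yl would give a comparable step on the pyridin-3-yl ring of compound 1, which already reads as a number.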